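The source may hold more compounds than are shown below. What is called first, only, known or untested is meant among the compounds shown, and "the series" means these compounds.

Measured so far:
- compound 1 `COc1cc(NC(=O)Nc2cc(Nc3ccc(C)c(C)c3)ncn2)cc(OC)c1`, a functional assay on HCC827 cells (Homo sapiens) for inhibition, read by MTT assay, with a stated time of 48 h, tested at 10 uM; a lower number here means less inhibition, a higher number more inhibition at the concentration tested (going by the name of the read-out): 45.7%
- compound 2 `COc1cc(NC(=O)Nc2cc(Nc3ccc(OC)c(C)c3)ncn2)cc(OC)c1`, this assay: 48.3%

Among the measured compounds shown here, compound 2 gives the higher of the two numbers in this assay, but the only measured step, a number 2.6 percentage points higher from compound 1 to compound 2 (within the scatter), lies within the scatter, so compound 1 and compound 2 cannot be told apart on these data.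

Compound 3 `COc1cc(NC(=O)Nc2cc(Nc3ccc(OC)c(I)c3)ncn2)cc(OC)c1` differs from compound 2 by iodo in place of methyl on an aromatic carbon. For the measured compounds named here, no measured step exchanges a methyl for iodo. Going by the values given here, the single step available, a number 2.6 percentage points higher from compound 1 to compound 2 (within the scatter), replaces a different group on an aromatic carbon of the same ring and stays within the scatter; it does not speak directly to iodo. With nothing pointing to a shift in either direction, the expected step of a number 1.7 percentage points higher from compound 2 to compound 3 (within the scatter) is one not beyond the scatter, and the range is kept wide for want of a bearing step. Compound 3 is therefore estimated at 50%, expected between 30% and 70% in this assay.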

Compound 3, a percentage reported as inhibition, at one concentration (the size of the read-out at that concentration, not a potency): 61.7%
For compound 3 the middle estimate is 11.7 percentage points below the measured one; low and high end bracket the measured number.
By their numbers in this assay, from the lowest: compounds 1 and 2 (each within the scatter of the next); then compound 3.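

In this assay, among the compounds shown here, iodo in place of methyl on the aromatic carbon ortho to a methoxy group gives a number 13.4 percentage points higher from compound 2 to compound 3 (beyond the scatter), the first change that clears the scatter. The full exchange of 3,4-dimethylphenyl for 3-iodo-4-methoxyphenyl on the nitrogen reads the same way, with a number 16 percentage points higher from compound 1 to compound 3 (beyond the scatter), so this carbon responds to its substituent, whereas methoxy in place of methyl at another carbon of the same ring gave no readable step. No measurement at hand accounts for the size of this step.

Going by these compounds, whether the gain is particular to iodo or would also appear with bromo, chloro or trifluoromethyl at this carbon remains open. Equally open, on these data alone, is how an amine or a carboxylic acid would read there.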